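This account rests on a few compounds, and the source may have more. Where it says the series, first, only, none or still open, it means among the compounds named here.

Measured so far:

- compound 1, `O=C(CCCSc1nc(O)cc(CCc2ccccc2)n1)NO`: 205 nM
- compound 2, `O=C(CCCSc1nc(O)cc(-c2ccccc2)n1)NO`: 27 nM
- compound 3, `O=C(CCCCSc1nc(O)cc(CCc2ccccc2)n1)NO`: 40 nM

In an assay on isolated protein for inhibition of histone deacetylase HD2 (Zea mays) (a higher number here means a weaker inhibitor, a lower number a stronger inhibitor), compound 3 stands second highest of the three numbers, close to compound 2, the gap being within the scatter, and well below compound 1. For the measured compounds named here, the only step in the same direction is a 5.1-fold lower number from compound 1 to compound 3 (0.71 log units; beyond the scatter), a chain extension by one carbon.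

Compound 4, `O=C(CCCCCCCSc1nc(O)cc(CCc2ccccc2)n1)NO`, carries 3-(hydroxycarbamoyl)propyl in place of hydroxycarbamoyl on a saturated chain carbon, four bonds along the chain from a sulfur. Going by the values given here, this pushes the chain three carbons further than the single extension seen so far, so the one measured step is only a loose guide, and a continued gain is not assumed. For compound 4 in this assay a somewhat weaker result than compound 3 is expected, a 3.8-fold higher number from compound 3 to compound 4 (0.57 log units; beyond the scatter), estimated at 150 nM with a range of 40 nM to 600 nM.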

Compound 4, half-maximal inhibitory concentration: 90 nM
Compound 4: middle estimate off by 1.7-fold (0.22 log units), on the high side, and the stated range covers the measured number.
By their numbers in this assay, from the lowest: compounds 2 and 3 (each within the scatter of the next); then compound 4; then compound 1.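

In this assay, lengthening the chain at this position does not keep lowering the number: a 2.3-fold higher number from compound 3 to compound 4 (0.35 log units; beyond the scatter) gives back part of the earlier gain, while a 2.3-fold lower number from compound 1 to compound 4 (0.36 log units; beyond the scatter) keeps the 7-carbon-longer end of the series short of its shortest member in neither direction lost. Among compound 1, compound 3 and compound 4 the trend with chain length is therefore not steady, and compound 3 has the lowest number of the three. No evidence bearing on this turn is available.

Still open, as far as these compounds go, is how the intermediate chain lengths between compound 3 and compound 4 behave, and whether a still longer chain continues the rise. Also open, from the compounds shown here alone, is whether a carboxylic acid in place of the hydroxycarbamoyl end retains any inhibition.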